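The source may hold more compounds than are shown below. What is called first, only, known or untested is meant among the compounds shown, and "the series" means these compounds.

Compound 1 `O=S(=O)(c1ccccc1)c1c(OCCCCCCO)no[n+]1[O-]` carries a 6-hydroxyhexyl chain on the shared core; in a functional assay on KG-1 cells (Homo sapiens) for inhibition, read by MTT assay, with a stated time of 48 h (a lower number here means a stronger inhibitor, a higher number a weaker inhibitor), compound 1 gives "not determined" (no result reported), so it stands without a number. Its measured relatives are compound 2 `O=C(CCCOc1no[n+]([O-])c1S(=O)(=O)c1ccccc1)NO` and compound 3 `O=C(CCCCOc1no[n+]([O-])c1S(=O)(=O)c1ccccc1)NO`. In this assay compound 2 gives 1480 nM and compound 3 gives 1910 nM; the step of a 1.3-fold higher number from compound 2 to compound 3 (0.11 log units; within the scatter) shows that moving from hydroxycarbamoyl to (hydroxycarbamoyl)methyl stays within the scatter. Compound 4 `CC(C)(COc1no[n+]([O-])c1S(=O)(=O)c1ccccc1)C(=O)NO` differs from compound 1 by 1-(hydroxycarbamoyl)-1-methylethyl in place of 5-hydroxypentyl on a saturated chain carbon bound to an oxygen on an aromatic ring. Among the measured compounds shown here, no measured step covers this exchange directly, and the one related step was flat, so compound 4 is expected to land near compounds 2 and 3 with no shift beyond the scatter. Compound 4 is therefore estimated in this assay at 1600 nM, between 600 nM and 4500 nM.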

Compound 4, half-maximal inhibitory concentration: 6080 nM
For compound 4 the middle estimate is 3.8-fold (0.58 log units) below the measured one, outside the stated range (above it).
By their numbers in this assay, from the lowest: compounds 2 and 3 (each within the scatter of the next); then compound 4.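

In this assay, among the compounds shown here, 1-(hydroxycarbamoyl)-1-methylethyl at this position gives the first change beyond the scatter, with a 3.2-fold higher number from compound 3 to compound 4 (0.50 log units; beyond the scatter) and a 4.1-fold higher number from compound 2 to compound 4 (0.61 log units; beyond the scatter), both modest. The chain carrying the hydroxycarbamoyl group is therefore not indifferent to every change, although the earlier step between the two unbranched chains stayed flat. Nothing available accounts for this shift.

Compound 1 has no number, so its 6-hydroxyhexyl chain cannot be compared with the others. The compounds shown also leave open how a carboxylic acid in place of hydroxycarbamoyl, or a longer unbranched chain, would read.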